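Swapping the Aryl Ring on a Weakly Active Core

The source may hold more compounds than are shown below. What is called first, only, known or untested is meant among the compounds shown, and "the series" means these compounds.

compound 1: `COc1cc(C2=NN(C(C)=O)C(c3cccc(OC)c3OC)O2)cc(OC)c1OC` — 17.5%
compound 2: `COc1cc(C(=O)N/N=C/c2ccccc2F)cc(OC)c1OC` — 76.5%

In a functional assay on BGC-823 cells (Homo sapiens) for antiproliferative activity, read by MTT assay, tested at 5 uM (a lower number here means a weaker effect, a higher number a stronger effect of the compound at the concentration tested), compound 1 gives 17.5%, the lowest of the two numbers shown. Compound 2 gives 76.5%, a gap well beyond the scatter. Compound 3, `COc1cc(C2=NN(C(C)=O)C(c3ccc(F)c(F)c3)O2)cc(OC)c1OC`, keeps the core of compound 1 and differs in one group: 3,4-difluorophenyl in place of 2,3-dimethoxyphenyl on a saturated ring carbon. For the measured compounds named here, no measured pair shows what this swap does, so the expectation rests on compound 1 alone. A small upward change is expected, a number 10.5 percentage points higher from compound 1 to compound 3 (beyond the scatter), possibly not beyond the scatter. Compound 3 is estimated at 28%, with a range from 8% to 55%.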

Compound 3, a percentage reported as inhibition, at one concentration (the size of the read-out at that concentration, not a potency): 21.6%
Beside the measured number, compound 3's estimate is 6.4 percentage points above it; the measured number falls inside the stated range.
By their numbers in this assay, from the lowest: compounds 1 and 3 (each within the scatter of the next); then compound 2.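

In this assay, placing 3,4-difluorophenyl in place of 2,3-dimethoxyphenyl on the saturated ring carbon gives a number 4.1 percentage points higher from compound 1 to compound 3 (within the scatter), so the two compounds cannot be told apart. At this position, then, an aryl ring without hydrogen-bond acceptors and one with them read alike, and this exchange does not lift the core of compound 1 out of its weak range. Nothing measured here gives a reason for this result. As far as these compounds go, whether an amine or a carboxylic acid on this aryl ring would change the read-out stays open. So does whether a non-aromatic group, such as a longer alkyl chain, on this saturated ring carbon would do so.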